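The compounds below may be only part of what the source reports. "The series", "measured", "known", "first", "only" and "open" are said of these compounds alone.

Two compounds of this series have numbers in an ADME assay on HEL cells (Homo sapiens) for cytotoxicity, with a stated time of 3 days (a higher number here means that more compound is tolerated, a lower number that less compound is tolerated), so far. Compound 1 `Cc1cc(-c2cccc(F)c2)c2ncc(CSCCc3ccccc3)n2c1` gives 35 ug/mL in this assay. Compound 2 `COc1ccc(-c2cc(C)c3ncc(CSCCc4ccccc4)n3c2)cc1` gives 25.8 ug/mL in this assay, the lower of the two numbers, though its gap to compound 1 lies within the scatter, so the pair shows no real separation. For the measured compounds named here, compound 3 `Cc1cc(-c2cccs2)cn2c(CSCCc3ccccc3)cnc12` carries thiophen-2-yl in place of 4-methoxyphenyl on an aromatic carbon; no measured pair of this kind exists. For compound 3 the step of a 1.2-fold higher number from compound 2 to compound 3 (0.07 log units; within the scatter) is expected to stay inside the scatter, with no clear direction. Compound 3 is therefore estimated at 30 ug/mL in this assay, within 15 ug/mL to 60 ug/mL.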

Compound 3, half-maximal cytotoxic concentration: 32 ug/mL
Beside the measured number, compound 3's estimate is 1.1-fold (0.03 log units) below it; measured number inside the range.
By their numbers in this assay, from the lowest: compounds 2, 3 and 1 (each within the scatter of the next).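

For the compounds shown here, this is the first single-place comparison. In this assay, thiophen-2-yl in place of 4-methoxyphenyl on this aromatic carbon, two atoms from the ring nitrogen, gives a 1.2-fold higher number from compound 2 to compound 3 (0.09 log units; within the scatter). A five-membered aromatic ring with a sulfur atom and a six-membered aromatic ring of carbon only are therefore not separated at this position, and no supporting data offer an explanation for this result.

From the compounds shown here alone, whether an amine or a carboxylic acid at this position would give a number beyond the scatter remains open.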